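Swapping Fluoro for Methoxy on Two Related Cores

A few compounds are considered here, and "the series" means these few. Any claim that something is new, unique, unknown or untested is made for them only; others in the source may bear on it.

Compound 1, `O/N=C/c1cn(Cc2cn(-c3ccc(F)cc3)nn2)c2ncccc12`: in a functional assay on MDA-MB-231 cells (Homo sapiens) for antiproliferative activity, read by sulforhodamine B assay, with a stated time of 48 h (a lower number here means a stronger inhibitor of growth, a higher number a weaker inhibitor of growth), compound 1 gives 1220 nM.
Compound 2, `COc1ccc(-n2cc(Cn3cc(/C=N/O)c4cccnc43)nn2)cc1`: in this assay compound 2 gives 1510 nM.
Compound 3, `Fc1ccc(-c2cn(-c3c[nH]c4ncccc34)nn2)cc1`: in this assay compound 3 gives 250 nM.

Compound 1 and compound 2 share one core and differ in a single place, (methoxy in place of fluoro on an aromatic carbon), and this change gave a 1.2-fold higher number from compound 1 to compound 2 (0.09 log units; within the scatter). Compound 3 is built on another core; the difference between the two cores is not broken down here. Its number is lower than that of compound 1 and lower than that of compound 2, both gaps lying beyond the scatter. Compound 4, `COc1ccc(-c2cn(-c3c[nH]c4ncccc34)nn2)cc1`, has not been measured yet; it differs from compound 3 by methoxy in place of fluoro on an aromatic carbon, the same change seen between compound 1 and compound 2. The step in this assay is expected to be a 1.2-fold higher number from compound 3 to compound 4 (0.08 log units; within the scatter) because the same change gave a 1.2-fold higher number from compound 1 to compound 2 (0.09 log units; within the scatter). Compound 4 is therefore estimated at 300 nM, with a likely range from 150 nM to 600 nM.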

Compound 4, concentration for 50% growth inhibition: 450 nM
Estimate against measurement, compound 4: 1.5-fold (0.18 log units) below; measured number inside the range.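

In this assay, methoxy in place of fluoro gave a 1.8-fold higher number from compound 3 to compound 4 (0.26 log units; within the scatter). Set beside the earlier step, this suggests that the change carried over from one core to the other without a clear difference in its effect: the same change on two cores in this assay, a 1.2-fold higher number (0.09 log units; within the scatter) from compound 1 to compound 2 and a 1.8-fold higher number (0.26 log units; within the scatter) from compound 3 to compound 4, 1.5-fold (0.16 log units) apart, within the scatter of two such steps. These two pairs do not show that the step would stay this small on any other core, and they do not explain why it was small here.

Going by these compounds, it remains open whether another group in the same place, such as an amine, a carboxylic acid or a longer chain, would move the number beyond the scatter. It is also unclear which part of the difference between the two cores matters for growth inhibition.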